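A few compounds are considered here, and "the series" means these few. Any claim that something is new, unique, unknown or untested is made for them only; others in the source may bear on it.

Working notes on the series. All four compounds share one core; they differ in the group on the amide-type nitrogen and in the substituted phenyl. Compound 1 `CNC(=O)c1cc(Oc2cccc(NC(=S)Nc3ccc(F)c(F)c3)c2)ccn1` gives 30300 nM in a functional assay on HCT-116 cells (Homo sapiens) for cytotoxicity, read by MTT assay, with a stated time of 48 h; a higher number here means a weaker inhibitor, a lower number a stronger inhibitor. Compound 2 `CCNC(=O)c1cc(Oc2cccc(NC(=S)Nc3ccc(F)c(F)c3)c2)ccn1` gives 30300 nM in this assay, and the step of no change at the digits printed from compound 1 to compound 2 (within the scatter). Compound 3 `CNC(=O)c1cc(Oc2cccc(NC(=S)Nc3cccc(C(F)(F)F)c3)c2)ccn1` gives 25300 nM in this assay. On the numbers shown, compound 3 carries the smallest figure of the three, but the step of a 1.2-fold lower number from compound 1 to compound 3 (0.08 log units; within the scatter), and its gap to compound 2 is of the same small size, so nothing separates the three beyond repeat scatter.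

Compound 4 `CCNC(=O)c1cc(Oc2cccc(NC(=S)Nc3cccc(C(F)(F)F)c3)c2)ccn1` has not been measured. It differs from compound 3 by methyl in place of hydrogen on a saturated chain carbon bound to an amide-type nitrogen. Among the measured compounds shown here, the one measured step of this kind is no change at the digits printed from compound 1 to compound 2 (within the scatter), and it bears directly on the present step, since the rest of the molecule is held fixed in both pairs. For the measured compounds named here, no other measured step speaks to this change. The step of a 1.0-fold lower number from compound 3 to compound 4 (0.01 log units; within the scatter) is therefore expected to stay within the scatter, with no direction favoured. Compound 4 is estimated at 25000 nM in this assay, with a range from 12000 nM to 50000 nM.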

Compound 4, half-maximal inhibitory concentration: 19400 nM
Compound 4: middle estimate off by 1.3-fold (0.11 log units), on the high side; measured number inside the range.
By their numbers in this assay, from the lowest: compounds 4, 3, 1 and 2 (each within the scatter of the next).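

In this assay, methyl in place of hydrogen on a saturated chain carbon bound to an amide-type nitrogen now has a second reading with 3-(trifluoromethyl)phenyl in place of 3,4-difluorophenyl (a 1.3-fold lower number from compound 3 to compound 4 (0.12 log units; within the scatter)), and the two readings of this change agree: the same change on two cores in this assay, no change at the digits printed (within the scatter) from compound 1 to compound 2 and a 1.3-fold lower number (0.12 log units; within the scatter) from compound 3 to compound 4, 1.3-fold (0.12 log units) apart, within the scatter of two such steps.
The change of 3,4-difluorophenyl to 3-(trifluoromethyl)phenyl can also be read a second time, now with ethylcarbamoyl in place of methylcarbamoyl (a 1.6-fold lower number from compound 2 to compound 4 (0.19 log units; within the scatter)), and its two readings likewise agree: the same change on two cores in this assay, a 1.2-fold lower number (0.08 log units; within the scatter) from compound 1 to compound 3 and a 1.6-fold lower number (0.19 log units; within the scatter) from compound 2 to compound 4, 1.3-fold (0.12 log units) apart, within the scatter of two such steps.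
Across these four compounds, neither change therefore alters the reading of the other beyond the scatter, and neither change on its own gives a step beyond it.

On these data alone, whether a longer chain than ethyl, or an amine or a carboxylic acid carried on that chain, would give a step beyond the scatter stays open. Also open, as far as these compounds go, is whether a phenyl bearing a methoxy group or a nitrile in place of the fluorine-bearing groups would separate from these compounds in this assay.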